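Compound 1 to compound 4: phenyl replaced by hydrogen

The source may hold more compounds than are shown below. What is called first, only, known or untested is meant among the compounds shown, and "the series" means these compounds.

Measured so far in a functional assay on SF-268 cells (Homo sapiens) for antiproliferative activity, read by sulforhodamine B assay, with a stated time of 72 h; on this read-out lower numbers stand for stronger inhibition and higher numbers for weaker inhibition:
- compound 1 (`O=C1CS/C(=N/Nc2nncc3ccccc23)N1c1ccccc1`) gives 7 nM
- compound 2 (`Cc1cc(C)nc(NS(=O)(=O)c2ccc(Nc3nncc4ccccc34)cc2)n1`) gives 7.6 nM
- compound 3 (`O=S(=O)(Nc1nccs1)c1ccc(Nc2nncc3ccccc23)cc1`) gives 45 nM

Compound 1 sits at the low end of these numbers together with compound 2, the two lying within the scatter of each other. Compound 3 gives a higher number, beyond the scatter from both.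

Compound 4 (`O=C1CS/C(=N/Nc2nncc3ccccc23)N1`) keeps the core of compound 1 but carries hydrogen in place of phenyl on an amide-type nitrogen in a ring. Within the data shown here, no measured step touches this nitrogen. Among the measured compounds shown here, the only single-place comparison available is a 5.9-fold higher number from compound 2 to compound 3 (0.77 log units; beyond the scatter), a modest step that arises at a sulfonamide nitrogen, with 1,3-thiazol-2-yl in place of 4,6-dimethylpyrimidin-2-yl. It bears on the new change only loosely, as a guide to how far one substituent swap has moved the numbers in this set. A step of similar size towards a higher number in this assay is therefore expected, though the direction is a judgement and not an observation. For compound 4 the estimated value is 40 nM, with an expected range of 8 nM to 200 nM. This estimate amounts to an expected 5.7-fold higher number from compound 1 to compound 4 (0.76 log units; beyond the scatter), and the measurement is still to come.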

Compound 4, half-maximal inhibitory concentration: 6 nM
For compound 4 the middle estimate is 6.7-fold (0.82 log units) above the measured one; measured number outside the range, below it.
By their numbers in this assay, from the lowest: compounds 4, 1 and 2 (each within the scatter of the next); then compound 3.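

Position notes: in this assay, hydrogen in place of phenyl on the amide-type nitrogen in a ring gives a 1.2-fold lower number from compound 1 to compound 4 (0.07 log units; within the scatter), so this pair cannot be told apart on this read-out. The earlier compounds shown here carried no information on this nitrogen; this pair shows that, with the rest of the core of compound 1 unaltered, the phenyl and its 6 heavy atoms are not needed at this place for a number in the range of compound 1, since compound 4 has no heavy atom there. Nothing available here accounts for this result, and no measured property of either compound bears on it.

From the compounds shown here alone, open: the pair covers only the two ends of phenyl and hydrogen, so it remains unknown whether a methyl, a benzyl, a longer alkyl chain or a chain ending in a carboxylic acid on this nitrogen would stay within the scatter of compound 4 or move the number. The compounds shown also leave open whether this flat reading at the nitrogen holds in cell lines other than the one behind this assay.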